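Swapping the amide cap: expected tolerance of the new compound

This account rests on a few compounds, and the source may have more. Where it says the series, first, only, none or still open, it means among the compounds named here.

Compound 1, `Cn1c(-c2cccc([N+](=O)[O-])c2)cnc1NC(=O)c1ccc(F)cc1`, gives a limit of > 50000 nM in a toxicity assay on THP-1 cells (Homo sapiens) for inhibition; a lower number here means that less compound is tolerated, a higher number that more compound is tolerated.
Compound 2, `COc1ccc(-c2cnc(NC(=O)c3ccc([N+](=O)[O-])cc3)n2C)cc1`, gives a limit of > 100000 nM in this assay.
Compound 3, `COc1ccc(-c2cnc(NC(=O)CCc3ccccc3)n2C)cc1`, gives a limit of > 100000 nM in this assay.

None of the three compounds reaches a measurable toxic concentration: each value is a limit of the test, not a number. Compound 3 stands at the limit of > 100000 nM in this assay, at which 2 of the 3 values shown sit, and the same limit holds for compound 2, while compound 1 sits at the limit of > 50000 nM in this assay, at which 1 of the 3 values shown sits. Within these three, nothing can be ordered, since all three values are limits.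

Compound 4, `COc1ccc(-c2cnc(NC(=O)c3ccccc3C#N)n2C)cc1`, differs from compound 3 by one change: 2-cyanophenyl in place of phenethyl on a carbonyl carbon. The change is on the carbonyl carbon whose other neighbour is the amide-type nitrogen, with the shared core untouched.

With all three measured values sitting at limits, no step beyond the scatter is expected in this assay, and the step from compound 3 to compound 4 is estimated as a number no higher from compound 3 to compound 4 (the limit leaves the size open). Compound 4 is therefore expected to be tolerated at 100000 nM, with a range from 50000 nM to 200000 nM, most likely again reported only as a limit.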

Compound 4, half-maximal cytotoxic concentration: > 100000 nM
Compound 4: only a limit was reported; the forecaster's own chance of this, stated with the estimate: 80%; the middle value sits exactly at the limit.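

In this assay compound 4 gives > 100000 nM, which is a limit and not a number. For the compounds shown here, compound 3 also has only a limit, and no step between the two compounds can be read. The compounds shown leave open at what concentration, if any, each becomes toxic to these cells.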